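Benzylamino replaces 4-chlorophenyl in a series at its limit

The compounds below may be only part of what the source reports. "The series", "measured", "known", "first", "only" and "open" are said of these compounds alone.

Three compounds share one core and differ in the group on a carbonyl carbon: compound 1 (`Cc1ccc(S(=O)(=O)N[C@@H](CC(=O)NC(C)(C)C)C(=O)NCCNC(=O)c2cccc(O)c2)cc1`), compound 2 (`Cc1ccc(S(=O)(=O)N[C@@H](CC(=O)NC(C)(C)C)C(=O)NCCNC(=O)c2c(O)cccc2F)cc1`) and compound 3 (`Cc1ccc(S(=O)(=O)N[C@@H](CC(=O)NC(C)(C)C)C(=O)NCCNC(=O)c2ccc(Cl)cc2)cc1`). All three were tested in an ADME assay on HepG2 cells (Homo sapiens) for cytotoxicity (a lower number here means that less compound is needed, a higher number that more compound is needed for the effect), and none gave an exact number. Compound 1 reads > 11000 nM as a limit of the assay. Compound 2 reads > 11000 nM as a limit too. Compound 3 reads > 11000 nM as a limit as well. The set therefore shows the limit of > 11000 nM in this assay, at which 3 of the 3 values shown sit, and gives compound 3 no exact place of its own.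

Compound 4 (`Cc1ccc(S(=O)(=O)N[C@@H](CC(=O)NC(C)(C)C)C(=O)NCCNC(=O)NCc2ccccc2)cc1`) carries benzylamino in place of 4-chlorophenyl on a carbonyl carbon and so turns (4-chlorophenyl)carbonyl into benzylcarbamoyl. The measured steps at this same place are a step that the two limits leave unreadable from compound 1 to compound 2 and a step that the two limits leave unreadable from compound 1 to compound 3 and a step that the two limits leave unreadable from compound 2 to compound 3 and none of them has a readable size.

Compound 3 sits at > 11000 nM as a limit, so compound 4 is expected to stay at that limit too. The expected step is a step that the limit leaves unreadable from compound 3 to compound 4 in this assay with no direction expected beyond the scatter. For compound 4 the estimate is 20000 nM with an expected range from 11000 nM to 60000 nM and most likely only a limit will be reported.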

Compound 4, half-maximal effective concentration: > 11000 nM
Compound 4 gave a limit, no number; the forecaster's own chance of this, stated with the estimate: 85%; the middle value is on the limit's open side.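

Within the data shown here, no step among compound 1, compound 2, compound 3 and compound 4 can be read in this assay, because all four give only the same limit and no exact number: the limit of > 11000 nM in this assay, at which 4 of the 4 values shown sit. The compounds shown leave open whether swapping the group on the carbonyl carbon, benzylamino included, changes the amount of compound needed for the effect.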